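Swapping a Fluoro for Methoxy on the Fused Ring

This account rests on a few compounds, and the source may have more. Where it says the series, first, only, none or still open, it means among the compounds named here.

Measured so far:
- compound 1 `O=C(CN1CCN(C(=O)c2cccc(Cl)c2)CC1)N1CCN(CCCc2c[nH]c3ccc(F)cc23)CC1`: 66200 nM
- compound 2 `O=C(CN1CCN(C(=O)c2cccc(Br)c2)CC1)N1CCN(CCCc2c[nH]c3ccc(F)cc23)CC1`: 40600 nM
- compound 3 `O=C(CN1CCN(C(=O)c2cccc(F)c2)CC1)N1CCN(CCCc2c[nH]c3ccc(F)cc23)CC1`: 83000 nM

In an ADME assay on HEK293 cells (Homo sapiens) for cytotoxicity, read by MTT assay, with a stated time of 72 h (a lower number here means a stronger inhibitor, a higher number a weaker inhibitor), compound 3 gives the highest of the three numbers; its gap to compound 1 lies within the scatter, while the step of a 2.0-fold higher number from compound 2 to compound 3 (0.31 log units; beyond the scatter) is the only one beyond it. The other two steps, a 1.6-fold lower number from compound 1 to compound 2 (0.21 log units; within the scatter) and a 1.3-fold higher number from compound 1 to compound 3 (0.10 log units; within the scatter), are both within the scatter.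

Compound 4 `COc1ccc2[nH]cc(CCCN3CCN(C(=O)CN4CCN(C(=O)c5cccc(F)c5)CC4)CC3)c2c1` differs from compound 3 by methoxy in place of fluoro on an aromatic carbon. Going by the values given here, none of the measured steps touches this position; all three exchange a halogen on an aromatic carbon elsewhere and stay small. Compound 4 is therefore expected to show no step beyond the scatter, a 1.0-fold lower number from compound 3 to compound 4 (0.02 log units; within the scatter). The estimate for compound 4 is 80000 nM, between 40000 nM and 160000 nM.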

Compound 4, half-maximal inhibitory concentration: > 200000 nM
Compound 4 ended at the assay's limit (the forecaster's own chance of this, stated with the estimate: 25%); at least 2.5-fold (0.39 log units) between middle value and limit.
By their numbers in this assay, from the lowest: compounds 2, 1 and 3 (each within the scatter of the next, the first and the last beyond it). At a limit, above all of these: compound 4.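

In this assay, the change from 5-fluoro-1H-indol-3-yl to 5-methoxy-1H-indol-3-yl gives an at least 2.4-fold higher number from compound 3 to compound 4 (0.38 log units; beyond the scatter), a larger step than any of the earlier halogen exchanges elsewhere in the molecule. Compound 4 stands at a limit, not at a number: the limit of > 200000 nM in this assay, at which 1 of the 4 values shown sits.

Going by these compounds alone, this aromatic carbon, untouched by the earlier steps, is thus a place where one exchange moves the number beyond the scatter, though the full size of that step stays unknown. The compounds shown leave open whether an amine or a hydroxy group here would do the same. They also leave open whether methoxy would have this effect with chloro or bromo on the other aromatic ring.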